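This account rests on a few compounds, and the source may have more. Where it says the series, first, only, none or still open, it means among the compounds named here.

In a functional assay on HepG2 cells (Homo sapiens) for antiproliferative activity, read by MTT assay, with a stated time of 72 h (a lower number here means a stronger inhibitor, a higher number a weaker inhibitor), compound 2 `Cn1cc(-c2nn(Cc3ccc(C(=O)NC4CCCC4)cc3)c(=O)c3ccccc23)cn1` gives 84300 nM. Of the compounds shown here, two have been measured so far, and compound 2 cannot be separated from compound 1 `Cn1cc(-c2nn(Cc3ccc(C(=O)N4CCCCC4)cc3)c(=O)c3ccccc23)cn1`, which gives 73100 nM in this assay, because the step of a 1.2-fold higher number from compound 1 to compound 2 (0.06 log units; within the scatter) lies within the scatter. Compound 3 `Cn1cc(-c2nn(Cc3ccc(C(=O)NC4CC4)cc3)c(=O)c3ccccc23)cn1` differs from compound 2 at the same amide-type nitrogen: cyclopropyl in place of cyclopentyl on an amide-type nitrogen. Within the data shown here, the only measured step that bears on this position, a 1.2-fold higher number from compound 1 to compound 2 (0.06 log units; within the scatter), exchanged one ring-shaped group for another on the carbonyl carbon and produced no change beyond the scatter. With a single step of that kind to go on, and it a small one, the expectation for compound 3 is a number close to that of compound 2, with no step beyond the scatter in either direction, so the expected step is a 1.0-fold lower number from compound 2 to compound 3 (0.00 log units; within the scatter). Compound 3 is therefore estimated at 84000 nM, within a range of 40000 nM to 180000 nM.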

Compound 3, half-maximal inhibitory concentration: > 100000 nM
Compound 3: only a limit was reported (the forecaster's own chance of this, stated with the estimate: 10%); at least 1.1-fold (0.07 log units) between middle value and limit.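

Compound 3 gives > 100000 nM in this assay, and this is a limit of the assay, not a number. Read as floors, the steps are an at least 1.1-fold higher number from compound 2 to compound 3 (0.07 log units; that floor lies within the scatter) and an at least 1.3-fold higher number from compound 1 to compound 3 (0.13 log units; that floor lies within the scatter), so cyclopropyl on the amide-type nitrogen brings no gain over cyclopentyl or piperidin-1-yl, though how far the true value lies past the limit stays unknown. This position has now carried three different ring groups with no number falling clear of the others, and one of those readings stops at the top of the assay's range: the limit of > 100000 nM in this assay, at which 1 of the 3 values shown sits.

Still open, from the compounds shown here alone, is whether a straight butyl chain, or a ring carrying an amine or a carboxylic acid, on the amide-type nitrogen would give a clearly lower number. Going by these compounds, how changes to the shared core would act also stays open.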